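Halogen swap in a diaryl urea series: compound 4 expected

The compounds below may be only part of what the source reports. "The series", "measured", "known", "first", "only" and "open" are said of these compounds alone.

Compound 1 `Cc1cc(C)nc(Oc2ccc(NC(=O)Nc3ccc(F)cc3)cc2)n1`: in a functional assay on MCF7 cells (Homo sapiens) for cytotoxicity, read by MTT assay, with a stated time of 3 days (on this read-out lower numbers stand for stronger inhibition and higher numbers for weaker inhibition), compound 1 gives > 50000 nM, a limit of the assay and not a number.
Compound 2 `Cc1cc(C)nc(Oc2ccc(NC(=O)Nc3ccc(Cl)cc3)cc2)n1`: in this assay compound 2 gives > 50000 nM, again a limit of the assay.
Compound 3 `Cc1cc(C)nc(Sc2ccc(NC(=O)Nc3ccc(F)cc3)cc2)n1`: in this assay compound 3 gives > 50000 nM, also a limit of the assay.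

The three measured ureas share a pattern of a fluoro or chloro substituent on one aryl ring and a dimethylpyrimidine attached through either an oxygen or a sulfur. Compound 2 differs from compound 1 by chloro in place of fluoro on an aromatic carbon, and the step that the two limits leave unreadable from compound 1 to compound 2 cannot be read, since both values are limits. Compound 3 and compound 1 differ in their cores, and that difference is not broken down here; what the two values show is that both stand at the limit.

Compound 4 `Cc1cc(C)nc(Sc2ccc(NC(=O)Nc3ccc(Cl)cc3)cc2)n1` is not yet measured. It differs from compound 3 by chloro in place of fluoro on an aromatic carbon, the same change that turns compound 1 into compound 2, with the same surroundings at the place of the exchange. Because (the limit of > 50000 nM in this assay, at which 3 of the 3 values shown sit), every measured point in this series sits at the assay ceiling, so the earlier step gives no readable size to carry over.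

The step that the limit leaves unreadable from compound 3 to compound 4 is expected to be essentially flat, resting on compound 3 at > 50000 nM and on the unreadable step from compound 1 to compound 2. Compound 4 is therefore expected to give about 60000 nM, with a plausible range from 20000 nM to 150000 nM, most likely reported as a limit as well.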

Compound 4, half-maximal inhibitory concentration: 35300 nM
Beside the measured number, compound 4's estimate is 1.7-fold (0.23 log units) above it; the range from low to high includes it.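

Chloro in place of fluoro on the core with the sulfur link gives, in this assay, an at least 1.4-fold lower number from compound 3 to compound 4 (0.15 log units; that floor lies within the scatter), so the step has a floor but no full size, and that floor alone does not clear the usual scatter. The same exchange on the core with the oxygen link cannot be read, since both of its ends are limits of the assay and not numbers, so the compounds show neither that the change carries from one core to the other nor that it fails to. The series gives only one measured number against a shared ceiling, which leaves any comparison between the two cores one-sided: the limit of > 50000 nM in this assay, at which 3 of the 4 values shown sit.

The compounds shown leave open whether a 4-bromophenyl or a 4-methoxyphenyl group in place of the 4-chlorophenyl would give a number further from that ceiling, and whether any such gain would hold on both cores. They also leave open how an amine link in place of the sulfur or the oxygen would read, or how a carboxylic acid or a longer chain on the aryl ring would read in this assay.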